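Side-group swap on the saturated ring carbon: compound 3

The source may hold more compounds than are shown below. What is called first, only, known or untested is meant among the compounds shown, and "the series" means these compounds.

Going by the values given here, compound 2 `OCCC(NC1CCN(CCCc2c[nH]c3ccc(-n4cnnc4)cc23)CC1)c1ccccc1` gives 100% in a functional assay on CHO cells for activation of 5-hydroxytryptamine receptor 1D (Homo sapiens), read by GTPgammaS binding (on this read-out lower numbers stand for smaller maximal responses and higher numbers for larger maximal responses), the highest of the two numbers measured so far; compound 1 `O=S(=O)(NCC1CCN(CCCc2c[nH]c3ccc(-n4cnnc4)cc23)CC1)c1ccccc1` gives 73%, and the step of a number 27 percentage points higher from compound 1 to compound 2 (beyond the scatter) is the only measured step. Compound 3 `CN(Cc1ccccc1)CC1CCN(CCCc2c[nH]c3ccc(-n4cnnc4)cc23)CC1` carries the change ((benzyl(methyl)amino)methyl in place of (3-hydroxy-1-phenylpropyl)amino on a saturated ring carbon). That single measured step exchanged a group at the same saturated ring carbon and moved the maximal response by a modest amount, so a step beyond the scatter is possible here, more likely downward from the top of the observed range. Compound 3 is therefore expected to reach 85% (range 65% to 100%), an estimated step of a number 15 percentage points lower from compound 2 to compound 3 (beyond the scatter).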

Compound 3, largest response reached (reported as efficacy), in percent of the reference or control that the assay uses: 93%
The estimate for compound 3 lay 8 percentage points below the measured number; low and high end bracket the measured number.
By their numbers in this assay, from the lowest: compound 1; then compounds 3 and 2 (each within the scatter of the next).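

In this assay, the step of a number 7 percentage points lower from compound 2 to compound 3 (within the scatter) shows that this saturated ring carbon tolerates (benzyl(methyl)amino)methyl, with 0 hydrogen-bond donors, in place of (3-hydroxy-1-phenylpropyl)amino, with no change beyond the scatter. The step of a number 20 percentage points higher from compound 1 to compound 3 (beyond the scatter) shows that, on the same methylene linker, benzyl(methyl)amino gives a response beyond the scatter of that with (phenylsulfonyl)amino. No measurement bearing on these steps is available. Open, on these data alone, is whether a primary amine or a carboxylic acid on this saturated ring carbon would keep the maximal response.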